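Adding (4-methylpiperazin-1-yl)methyl to compound 2

The compounds below may be only part of what the source reports. "The series", "measured", "known", "first", "only" and "open" are said of these compounds alone.

Compound 1 `Nc1n[nH]c2cccc(C#Cc3cccc(NC(=O)c4cc(F)cc(C(F)(F)F)c4)c3)c12` gives 2140 nM
Compound 2 `Nc1n[nH]c2cccc(C#Cc3cccc(C(=O)Nc4cccc(C(F)(F)F)c4)c3)c12` gives 3470 nM

In a functional assay on K562 cells (Homo sapiens) for inhibition, read by MTT assay, with a stated time of 72 h (on this read-out lower numbers stand for stronger inhibition of growth and higher numbers for weaker inhibition of growth), compound 2 lies within the usual scatter of compound 1, so the two cannot be ranked. Compound 3 `CN1CCN(Cc2cc(NC(=O)c3cccc(C#Cc4cccc5[nH]nc(N)c45)c3)cc(C(F)(F)F)c2)CC1` differs from compound 2 by (4-methylpiperazin-1-yl)methyl in place of hydrogen on an aromatic carbon and the new group sits meta to a trifluoromethyl group. Among the compounds with values here, no measured pair shows what such a change does, so any forecast is a judgement. The expected step is a 12-fold lower number from compound 2 to compound 3 (1.06 log units; beyond the scatter) in this assay toward stronger inhibition of growth, beyond the scatter. Compound 3 is estimated at 300 nM in this assay (expected range 40 nM to 1500 nM).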

Compound 3, concentration for 50% growth inhibition: 300 nM
Compound 3: the middle estimate sits on the measured number at the digits printed, within the range that was stated.
By their numbers in this assay, from the lowest: compound 3; then compounds 1 and 2 (each within the scatter of the next).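

In this assay, adding (4-methylpiperazin-1-yl)methyl on this aromatic carbon, meta to a trifluoromethyl group, gives a 12-fold lower number from compound 2 to compound 3 (1.06 log units; beyond the scatter) and is the first structural change shown here with a measured step. This position therefore accepts a large group that carries a non-aromatic ring, and growth inhibition becomes stronger rather than being lost. Nothing measured here bears on the reason for this step.

Going by these compounds, whether a morpholine ring or a simple dimethylamine, joined through the same carbon, would do as much stays open. So does whether the same addition would strengthen compound 1 to a similar extent.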